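Working notes: from compound 3 to compound 4

The compounds below may be only part of what the source reports. "The series", "measured", "known", "first", "only" and "open" are said of these compounds alone.

Compound 1 `C=C(Br)C(=O)Nc1ccc2c(c1)/C(=C\c1sccc1C)C(=O)N2`: 340 nM
Compound 2 `C=C(Br)C(=O)Nc1ccc2c(c1)/C(=C/c1ccc[nH]1)C(=O)N2`: 110 nM
Compound 3 `C=C(Br)C(=O)Nc1ccc2c(c1)/C(=C/c1ccc(C)s1)C(=O)N2`: 360 nM
Compound 4 `C=C(Br)C(=O)Nc1ccc2c(c1)/C(=C/c1sccc1C)C(=O)N2`: not yet measured

All values come from a functional assay on Jurkat cells (Homo sapiens) for antiproliferative activity, read by MTT assay, with a stated time of 72 h; a lower number here means a stronger inhibitor, a higher number a weaker inhibitor. Compound 3 at 360 nM lies within the scatter of compound 1 at 340 nM, and it is separated from compound 2 by a gap beyond the scatter.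

The change under consideration is 3-methylthiophen-2-yl in place of 5-methylthiophen-2-yl on a double-bonded chain carbon bound to a double-bonded ring carbon: 3-methylthiophen-2-yl in place of 5-methylthiophen-2-yl, on a double-bonded chain carbon bound to a double-bonded ring carbon. Within the data shown here, only one measured step bears on it directly, a 3.3-fold higher number from compound 2 to compound 3 (0.51 log units; beyond the scatter). That step is modest and replaces 1H-pyrrol-2-yl, so it exchanges a different ring, whereas here the ring type stays the same. Compound 1, which also carries 3-methylthiophen-2-yl, gives 340 nM. No step beyond the scatter is therefore expected, and no direction is favoured.

The expected change is a 1.1-fold lower number from compound 3 to compound 4 (0.04 log units; within the scatter). Compound 4 is estimated at 330 nM, with an expected range of 140 nM to 800 nM.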

Compound 4, half-maximal inhibitory concentration: 530 nM
For compound 4 the middle estimate is 1.6-fold (0.21 log units) below the measured one; low and high end bracket the measured number.
By their numbers in this assay, from the lowest: compound 2; then compounds 1, 3 and 4 (each within the scatter of the next).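

In this assay, shifting the methyl on the thiophene ring does not register, as 3-methylthiophen-2-yl in place of 5-methylthiophen-2-yl gives a 1.5-fold higher number from compound 3 to compound 4 (0.17 log units; within the scatter). Among these compounds, the exchange of 1H-pyrrol-2-yl remains the only change here to exceed the scatter, now seen with a second thiophene as well, with a 4.8-fold higher number from compound 2 to compound 4 (0.68 log units; beyond the scatter). The double bond drawn E or Z likewise shows no step beyond the scatter, with a 1.6-fold higher number from compound 1 to compound 4 (0.19 log units; within the scatter), and this step isolates configuration as drawn: the fact that compounds 1 and 4 differ only in the configuration as drawn.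

The compounds shown leave open whether a methyl on the 1H-pyrrol-2-yl ring would be tolerated as it is on thiophene. They also leave open whether an amine or a carboxylic acid at this place would move the number beyond the scatter.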